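Aryl swap at the shared core: compound 3 to compound 4

The source may report more compounds than this note shows. Statements on the series, on what has been measured and on what is new or still open speak of the compounds shown alone.

In an assay for binding affinity to dual specificity mitogen-activated protein kinase kinase 4 (Homo sapiens), read by KINOMEscan, tested at 100 nM (a higher number here means a weaker effect of the compound at the concentration tested, a lower number a stronger effect), compound 1 `CCCS(=O)(=O)Nc1ccc(F)c(C(=O)c2n[nH]c3ncc(-c4ccccc4F)cc23)c1F` gives 2%. Compound 2 `CCCS(=O)(=O)Nc1ccc(F)c(C(=O)c2n[nH]c3ncc(-c4ccc(O)cc4)cc23)c1F` gives 0.75%. Compound 3 `CCCS(=O)(=O)Nc1ccc(F)c(C(=O)c2n[nH]c3ncc(-c4ccc(C)c(C)c4)cc23)c1F` gives 20%, the highest of the three numbers, reached by a number 18 percentage points higher from compound 1 to compound 3 (beyond the scatter) and by a number 19.3 percentage points higher from compound 2 to compound 3 (beyond the scatter). Compound 4 `CCCS(=O)(=O)Nc1ccc(F)c(C(=O)c2n[nH]c3ncc(-c4ccc(OC)cc4Cl)cc23)c1F` is the unmeasured member; the change is 2-chloro-4-methoxyphenyl in place of 3,4-dimethylphenyl on an aromatic carbon. Both steps into compound 3 bear on it: leaving the 3,4-dimethylphenyl for either other aryl went with a lower number in this assay, and a number 1.3 percentage points lower from compound 1 to compound 2 (within the scatter) places those two aryls close together. A fall is therefore expected, a number 12 percentage points lower from compound 3 to compound 4 (beyond the scatter), though no measured aryl carries chlorine or methoxy, so the size is uncertain. Compound 4 is estimated at 8%, with a range from 1% to 35%.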

Compound 4, a percentage reported as activity, at one concentration (the size of the read-out at that concentration, not a potency): 5.3%
Compound 4: middle estimate off by 2.7 percentage points, on the high side, within the range that was stated.
By their numbers in this assay, from the lowest: compounds 2, 1 and 4 (each within the scatter of the next); then compound 3.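

Working from this assay, the aryl swap gives a number 14.7 percentage points lower from compound 3 to compound 4 (beyond the scatter) and so puts a ring carrying chlorine and methoxy with the aryls of the low numbers. The other two steps, a number 4.6 percentage points higher from compound 2 to compound 4 (within the scatter) and a number 3.3 percentage points higher from compound 1 to compound 4 (within the scatter), leave compounds 1, 2 and 4 unordered, so among the four aryls at this position only the 3,4-dimethylphenyl of compound 3 stands apart. No supporting data explain this difference.

Whether chlorine or methoxy alone accounts for the step remains open. Also open, on these data alone, is how an amine or a carboxylic acid on this aryl ring would read.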